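A few compounds are considered here, and "the series" means these few. Any claim that something is new, unique, unknown or untested is made for them only; others in the source may bear on it.

Compound 3 `C=CC[C@H]1C[C@]2([C@@H](C)Cc3cc(N)c(OC)cc3F)OCOC2=CC1=O` gives 160 nM in a functional assay on NCI-H460 cells (Homo sapiens) for antiproliferative activity, with a stated time of 72 h (a higher number here means a weaker inhibitor, a lower number a stronger inhibitor), the second highest of the three numbers measured, though all three lie within the scatter of one another. Compound 2 `C=CC[C@H]1C[C@]2([C@@H](C)Cc3cc(OC)c(OC)cc3F)OCOC2=CC1=O` gives 120 nM, and a 1.3-fold higher number from compound 2 to compound 3 (0.12 log units; within the scatter). Compound 1 `C=CC[C@H]1C[C@]2([C@@H](C)Cc3ccc(OC)c(NC(C)=O)c3)OCOC2=CC1=O`, which also carries an acetamido group, gives 310 nM; the values of compound 1 and compound 3 sit within the scatter of each other. Compound 4 `C=CC[C@H]1C[C@]2([C@@H](C)Cc3cc(NC(C)=O)c(OC)cc3F)OCOC2=CC1=O` differs from compound 3 by acetyl in place of hydrogen on a nitrogen on an aromatic ring. Within the data shown here, no measured step covers this change directly; the only related observation is that compound 1, bearing an acetamido, gives a number within the scatter of compound 3. Compound 4 is therefore expected to show a 1.3-fold higher number from compound 3 to compound 4 (0.10 log units; within the scatter), nothing beyond the scatter. The estimated value for compound 4 is 200 nM, between 80 nM and 500 nM.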

Compound 4, half-maximal inhibitory concentration: 71 nM
Compound 4: the middle estimate sits 2.8-fold (0.45 log units) above what was measured; the measured number lies below the stated range.
By their numbers in this assay, from the lowest: compounds 4, 2, 3 and 1 (each within the scatter of the next, the first and the last beyond it).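

In this assay, among these compounds, acetyl on the nitrogen of the aromatic amino group gives a 2.3-fold lower number from compound 3 to compound 4 (0.35 log units; beyond the scatter) and so shows that this nitrogen accepts the change, with a step beyond the scatter that the earlier compounds did not show. Acetamido in place of methoxy gives a 1.7-fold lower number from compound 2 to compound 4 (0.23 log units; within the scatter) and so sets no order between those two, while fluoro in place of hydrogen, with the acetamido present in both, gives a 4.4-fold lower number from compound 1 to compound 4 (0.64 log units; beyond the scatter) and adds a second step beyond the scatter. Nothing given here explains either step. The compounds shown leave open whether a longer acyl chain such as propionyl, or a methanesulfonyl group, on this nitrogen would give a number like that of compound 4.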